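The source may hold more compounds than are shown below. What is called first, only, known or untested is meant among the compounds shown, and "the series" means these compounds.

Measured compounds:
compound 1, `CCc1ccc2[nH]c(=O)c(CN(Cc3ccc(C(C)(C)C)cc3)[C@@H](C)c3ccc(OC)cc3)cc2c1` — > 5000 nM
compound 2, `COc1ccc([C@H](C)N(Cc2ccc(C(C)(C)C)cc2)Cc2cc3cc(OC)ccc3[nH]c2=O)cc1` — 4100 nM
compound 3, `CCc1ccc2[nH]c(=O)c(CN(Cc3ccc(C(C)(C)C)cc3)C(C)c3ccc(OC)c(Cl)c3)cc2c1` — > 10000 nM

The read-out in every case is a toxicity assay on MDCK cells (Canis lupus familiaris) for cytotoxicity, read by crystal violet staining, with a stated time of 48 h; on this read-out higher numbers stand for lower toxicity in this test and lower numbers for higher toxicity in this test. For compound 1 the value > 5000 nM is a limit of the assay and not a number. For compound 3 the value > 10000 nM is likewise a limit. Compound 2 gives a number, 4100 nM.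

Compound 2 differs from compound 1 by one change, (methoxy in place of ethyl on an aromatic carbon). The step it made is an at least 1.2-fold lower number from compound 1 to compound 2 (0.08 log units; that floor lies within the scatter). Compound 3 differs from compound 1 by 1-(3-chloro-4-methoxyphenyl)ethyl in place of 1-(4-methoxyphenyl)ethyl on an amine nitrogen, which is how the two cores differ here. The step between them is a step that the two limits leave unreadable from compound 1 to compound 3, and it cannot be read because the limit of > 5000 nM in this assay, at which 1 of the 3 values shown sits, and the limit of > 10000 nM in this assay, at which 1 of the 3 values shown sits, are both limits rather than numbers.

The unmeasured compound 4, `COc1ccc2[nH]c(=O)c(CN(Cc3ccc(C(C)(C)C)cc3)C(C)c3ccc(OC)c(Cl)c3)cc2c1`, is reached from compound 3 by methoxy in place of ethyl on an aromatic carbon. This is the same change as from compound 1 to compound 2, at the same place. The earlier step was small and within the usual scatter, so a step of similar small size is expected from compound 3 to compound 4 in this assay, namely an at least 1.2-fold lower number from compound 3 to compound 4 (0.09 log units; that floor lies within the scatter). This rests on the step of an at least 1.2-fold lower number from compound 1 to compound 2 (0.08 log units; that floor lies within the scatter) and on compound 3 standing at a limit with > 10000 nM. The estimate for compound 4 is therefore 8000 nM, expected to lie between 3000 nM and 20000 nM, with a fair chance that only a limit is reported.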

Compound 4, half-maximal cytotoxic concentration: > 10000 nM
Compound 4 was reported as a limit; the forecaster's own chance of this, stated with the estimate: 50%; middle value at least 1.2-fold (0.09 log units) from the limit.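

Methoxy in place of ethyl on the aromatic carbon was carried onto the core of compound 3, but that step and the step from compound 1 to compound 3 cannot be read, because in each pair both values are limits: the limit of > 10000 nM in this assay, at which 2 of the 4 values shown sit; (the limit of > 5000 nM in this assay, at which 1 of the 4 values shown sits). Among these compounds, the one new step that can be read in this assay belongs to the other change, 1-(3-chloro-4-methoxyphenyl)ethyl in place of 1-(4-methoxyphenyl)ethyl on the amine nitrogen, and it is an at least 2.4-fold higher number from compound 2 to compound 4 (0.38 log units; beyond the scatter). This shows that the change on the amine nitrogen goes with lower toxicity in this assay for this one pair with the methoxy group on the aromatic carbon, but it does not show that the same holds with ethyl there, or that methoxy in place of ethyl has the same effect with and without the chloro group.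

Numbers for both members of a pair would be needed to compare either change across the two cores. The compounds shown also leave open what this assay would give with another group on that aromatic carbon, such as a propyl chain, a hydroxy group or a carboxylic acid.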